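A few compounds are considered here, and "the series" means these few. Any claim that something is new, unique, unknown or untested is made for them only; others in the source may bear on it.

Measured in a functional assay on A549 cells (Homo sapiens) for antiproliferative activity, read by MTT assay, with a stated time of 48 h; on this read-out higher numbers stand for weaker inhibition and lower numbers for stronger inhibition:
- compound 1 `CC(=O)OC/C1=C/C[C@](C)(CCC=C(C)C)/C=C/[C@@H](OC(=O)C=C(C)C)[C@](C)(O)/C=C/C1=O`: 2950 nM
- compound 2 `COC/C1=C/C[C@](C)(CCC=C(C)C)/C=C/[C@@H](OC(=O)C=C(C)C)[C@](C)(O)/C=C/C1=O`: 3950 nM
- compound 3 `CC(C)=CCC[C@]1(C)/C=C/[C@@H](OC(=O)C=C(C)C)[C@](C)(O)/C=C/C(=O)/C(CN(C)C)=C\C1`: 590 nM

Of these three, compound 3 gives the lowest number, 590 nM, and so the strongest inhibition. The next compound, compound 4 `CC(C)=CCC[C@]1(C)/C=C/[C@@H](OC(=O)C=C(C)C)[C@](C)(O)/C=C/C(=O)/C(CN2CCN(C)CC2)=C\C1`, has not yet been measured. It differs from compound 3 by 4-methylpiperazin-1-yl in place of dimethylamino on a saturated chain carbon bound to a double-bonded ring carbon, with 4-methylpiperazin-1-yl in place of dimethylamino on a saturated chain carbon bound to a double-bonded ring carbon.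

Three measured steps changed this same place. Two of them brought in dimethylamino: a 5.0-fold lower number from compound 1 to compound 3 (0.70 log units; beyond the scatter) and a 6.7-fold lower number from compound 2 to compound 3 (0.83 log units; beyond the scatter). The third, a 1.3-fold higher number from compound 1 to compound 2 (0.13 log units; within the scatter), swapped one oxygen-linked group for another. Among the measured compounds shown here, no measured step replaces one amine with another, so the data do not show the size of this change directly. Since both groups are amines, compound 4 is expected to stay closer to compound 3 than to compound 1 or compound 2, perhaps with a slightly higher number. The expected change is a 1.5-fold higher number from compound 3 to compound 4 (0.18 log units; within the scatter), a small step that may not exceed the scatter. For compound 4, the estimated value in this assay is 900 nM, with an expected range of 300 nM to 2700 nM.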

Compound 4, half-maximal inhibitory concentration: 940 nM
Compound 4: middle estimate off by 1.0-fold (0.02 log units), on the low side; the measured number falls inside the stated range.
By their numbers in this assay, from the lowest: compounds 3 and 4 (each within the scatter of the next); then compounds 1 and 2 (each within the scatter of the next).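

In this assay the step to a larger amine group carrying a ring, a 1.6-fold higher number from compound 3 to compound 4 (0.20 log units; within the scatter), stays within the scatter, so dimethylamino is not the only amine that fits at this position. The gain over the oxygen-linked groups also appears with a second amine, since a 4.2-fold lower number from compound 2 to compound 4 (0.62 log units; beyond the scatter) and a 3.1-fold lower number from compound 1 to compound 4 (0.50 log units; beyond the scatter) are both beyond the scatter, and among these four compounds no amine goes against that pattern. Nothing measured here explains why the two amine groups sit so close together or why both give lower numbers than the oxygen-linked groups.

Still open, going by these compounds, is how much the second ring nitrogen of 4-methylpiperazin-1-yl matters. A morpholin-4-yl group, with oxygen at that ring position, or a piperidin-1-yl group, with carbon there, could show whether the number in this assay stays near those of compound 3 and compound 4.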